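One Extra Methyl on a Compound at the Limit

The compounds below may be only part of what the source reports. "The series", "measured", "known", "first", "only" and "open" are said of these compounds alone.

In a functional assay on A549 cells (Homo sapiens) for cytotoxicity, read by XTT assay, with a stated time of 72 h (a higher number here means a weaker inhibitor, a lower number a stronger inhibitor), compound 2 (`COc1ccc(C(O)c2ccc3c(ccn3C)c2)c(OC)c1OC`) gives > 10000 nM as its result. That entry is a limit of the assay and not a number. Compound 1 (`CCn1ccc2cc(Cc3ccc(OC)c(OC)c3OC)ccc21`) gives > 10000 nM in this assay and this entry is also only a limit. The whole picture so far is the limit of > 10000 nM in this assay, at which 2 of the 2 values shown sit, and neither compound has an exact half-maximal inhibitory concentration.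

Compound 3 (`CCn1ccc2cc(C(O)c3ccc(OC)c(OC)c3OC)ccc21`) comes from compound 2 through one small edit (methyl in place of hydrogen on a saturated chain carbon bound to an aromatic nitrogen) that places methyl in place of hydrogen on a saturated chain carbon bound to an aromatic nitrogen, turning methyl to ethyl. Among the compounds with values here, no measured pair shows what this edit does, so the expectation starts from compound 2 with its limit of > 10000 nM and assumes little movement. In this assay the estimated step of a number no higher from compound 2 to compound 3 (the limit leaves the size open) is expected to stay within the usual scatter, and the result may well be a limit again. For compound 3 the expected value is 10000 nM with an estimated range from 3000 nM to 30000 nM as the likely span.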

Compound 3, half-maximal inhibitory concentration: > 10000 nM
Compound 3 ended at the assay's limit; the forecaster's own chance of this, stated with the estimate: 75%; the middle value lies on the limit itself.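

In this assay compound 3 gives > 10000 nM as a limit of the assay and not a number. Compound 1 and compound 2 also stand at a limit, so neither step to compound 3 can be read: the limit of > 10000 nM in this assay, at which 3 of the 3 values shown sit. The compounds shown leave open how far any of these changes moves the half-maximal inhibitory concentration.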